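Amide nitrogen isomer: compound 3 to compound 4

The source may hold more compounds than are shown below. What is called first, only, known or untested is meant among the compounds shown, and "the series" means these compounds.

Compound 1 `C=CC1=C(C(=O)O)C(c2ccc(OC)cc2)OC1` is the free acid of the shared core. In a functional assay on A549 cells (Homo sapiens) for cytotoxicity, read by MTT assay, with a stated time of 24 h (a higher number here means a weaker inhibitor, a lower number a stronger inhibitor), compound 1 gives > 100000 nM, a limit of the assay rather than a number. Compound 2 `C=CC1=C(C(=O)NCC(C)C)C(c2ccc(F)cc2)OC1` carries an isobutyl amide on a fluorinated ring. In this assay compound 2 gives > 100000 nM, again only a limit. Compound 3 `C=CC1=C(C(=O)NCC(C)C)C(c2ccc(Cl)c(Cl)c2)OC1` has the same amide on a dichlorinated ring. In this assay compound 3 gives > 100000 nM, also a limit. Compound 3 therefore stands at the level of the whole set, as the limit of > 100000 nM in this assay, at which 3 of the 3 values shown sit, shows. Compound 4 `C=CC1=C(C(=O)NC(C)(C)C)C(c2ccc(Cl)c(Cl)c2)OC1` differs from compound 3 only in that (tert-butyl in place of isobutyl on an amide-type nitrogen). Among the compounds with values here, no measured step pairs such isomers, so no shift beyond the scatter is expected, a step that the limit leaves unreadable from compound 3 to compound 4. Compound 4 is expected to give 120000 nM, within 40000 nM to 400000 nM, most likely again reported as a limit.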

Compound 4, half-maximal inhibitory concentration: > 100000 nM
Compound 4: no number, only a limit; the forecaster's own chance of this, stated with the estimate: 85%; the middle value lies beyond the limit too.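

In this assay compound 4 gives > 100000 nM, a limit and not a number. No step from compound 3 to compound 4 can be read, because both compounds stand only as limits: the limit of > 100000 nM in this assay, at which 4 of the 4 values shown sit.

The compounds shown leave open what number, if any, the isobutyl and tert-butyl amides would reach in this assay.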